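Replacing the cyclohexylamino group of compound 2

This account rests on a few compounds, and the source may have more. Where it says the series, first, only, none or still open, it means among the compounds named here.

Compound 1 `COCCNc1nc(-c2ccccc2)nc2ccccc12` gives 27.5 ug/mL in a functional assay on A549 cells (Homo sapiens) for cytotoxicity, read by sulforhodamine B assay (a lower number here means a stronger inhibitor, a higher number a weaker inhibitor), so far
Compound 2 `c1ccc(-c2nc(NC3CCCCC3)c3ccccc3n2)cc1` gives 7.23 ug/mL in this assay so far
Compound 3 `CN(C)CCN(C)c1nc(-c2ccccc2)nc2ccccc12` has no measurement yet

Among the compounds with values here, compound 2 holds the lower of the two numbers, and compound 1 is its only neighbour. Going on to compound 3 puts (2-(dimethylamino)ethyl)(methyl)amino in place of cyclohexylamino on an aromatic carbon, next to the ring nitrogen: (2-(dimethylamino)ethyl)(methyl)amino in place of cyclohexylamino on an aromatic carbon is the counted change. Within the data shown here, one measured step bears on this: a 3.8-fold lower number from compound 1 to compound 2 (0.58 log units; beyond the scatter) came with cyclohexyl replacing 2-methoxyethyl, a modest move beyond the scatter. Among the measured compounds shown here, compound 3 gives up the same ring for an open chain, so a rise in this assay is expected, somewhat smaller than that step, since the entering chain is a different one and no measured compound carries it. The estimated move is a 2.1-fold higher number from compound 2 to compound 3 (0.32 log units; beyond the scatter) in this reading. For compound 3 the estimate is 15 ug/mL, with 5 ug/mL to 40 ug/mL as the expected range.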

Compound 3, half-maximal inhibitory concentration: 28.1 ug/mL
Beside the measured number, compound 3's estimate is 1.9-fold (0.27 log units) below it; the range from low to high includes it.
By their numbers in this assay, from the lowest: compound 2; then compounds 1 and 3 (each within the scatter of the next).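

In this assay, a second open chain at this aromatic carbon next to the ring nitrogen also gives a weaker result than cyclohexylamino, with a 3.9-fold higher number from compound 2 to compound 3 (0.59 log units; beyond the scatter) on the change to (2-(dimethylamino)ethyl)(methyl)amino. The two open chains do not separate, with a 1.0-fold higher number from compound 1 to compound 3 (0.01 log units; within the scatter) on the change from (2-methoxyethyl)amino, so compound 2 now stands apart from two different chains rather than from one. Nothing available explains why the ring-bearing compound gives the lower number.

The compounds shown leave open whether the ring itself or the hydrogen on the attached nitrogen goes with the lower number, as compound 3 differs from compound 2 in both. A cyclopentyl group, an unbranched hexyl chain or an N-methylcyclohexylamino group at this position would bear on that question.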